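This account rests on a few compounds, and the source may have more. Where it says the series, first, only, none or still open, it means among the compounds named here.

Measured in a functional assay on HL-60 cells (Homo sapiens) for antiproliferative activity, read by sulforhodamine B assay, with a stated time of 72 h; a higher number here means a weaker inhibitor, a lower number a stronger inhibitor:
- Compound 1 `CN(C)C(=S)N/N=C/c1ccc2ccccc2n1`: 50 nM
- Compound 2 `NC(=S)N/N=C/c1ccc2ccccc2n1`: > 100000 nM

Compound 2 has no exact number, only a limit: the limit of > 100000 nM in this assay, at which 1 of the 2 values shown sits. Compound 3 `Fc1ccc(NC(=S)N/N=C/c2ccc3ccccc3n2)cc1` differs from it by 4-fluorophenyl in place of hydrogen on an amide-type nitrogen, which is 4-fluorophenyl in place of hydrogen on an amide-type nitrogen. Going by the values given here, only one measured step bears on this change, and it is large: an at least 2000-fold higher number from compound 1 to compound 2 (3.30 log units; beyond the scatter). It shows that the groups on that end of the molecule can matter greatly, though dimethylamino is not 4-fluorophenyl. A large move toward a lower number, meaning a stronger inhibitor, is therefore expected. The expected step is an at least 100-fold lower number from compound 2 to compound 3 (2.00 log units; beyond the scatter). Compound 3 is estimated at 1000 nM, with an expected range of 80 nM to 20000 nM.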

Compound 3, half-maximal inhibitory concentration: 17000 nM
Compound 3: middle estimate off by 17-fold (1.23 log units), on the low side, and the stated range covers the measured number.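

Putting 4-fluorophenyl on the amide-type nitrogen gives, in this assay, an at least 5.8-fold lower number from compound 2 to compound 3 (0.76 log units; beyond the scatter). Compound 2 carries only a limit, so that step is a minimum and not an exact size: the limit of > 100000 nM in this assay, at which 1 of the 3 values shown sits.

Compound 3, at 17000 nM, still has a higher number than compound 1, at 50 nM, so this aromatic group does not match dimethylamino at that end of the molecule. Still open, on these data alone, is how a single methyl group or an unsubstituted phenyl on that nitrogen would compare. Also open, as far as these compounds go, is what the fluorine adds to the phenyl ring.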